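From ester to phenyl in a permeability series

A few compounds are considered here, and "the series" means these few. Any claim that something is new, unique, unknown or untested is made for them only; others in the source may bear on it.

Of the compounds shown here, three sharing part of their structure have been measured in an ADME assay on Caco-2 cells (Homo sapiens) for permeability; a lower number here means that the compound crosses the layer more slowly, a higher number that the compound crosses the layer faster. Compound 1 (`COC(=O)c1ccc(/C=C/C(=O)N[C@@H]2O[C@H](CO)[C@@H](O)[C@H](O)[C@H]2O)cc1`) gives 26.3 nm/s, and compound 2 (`COc1ccc(/C=C/C(=O)N[C@@H]2O[C@H](CO)[C@@H](O)[C@H](O)[C@H]2O)c(O)c1`) gives 38.9 nm/s. These two numbers lie within the scatter of each other, so they cannot be told apart. Compound 3 (`CC[C@H](CC(=O)N[C@@H]1O[C@H](CO)[C@@H](O)[C@H](O)[C@H]1O)c1ccc(C)c(C)c1`) gives 76.7 nm/s, which stands higher than the number for compound 1 by more than the scatter.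

Compound 4 (`O=C(/C=C/c1ccc(-c2ccccc2)cc1)N[C@@H]1O[C@H](CO)[C@@H](O)[C@H](O)[C@H]1O`) has not yet been measured. It keeps the core of compound 1 and changes one group: phenyl in place of methoxycarbonyl on an aromatic carbon, para to a large group (phenyl in place of methoxycarbonyl on an aromatic carbon). Among the compounds with values here, no two measured compounds differ in just one place, so the data offer no direct measure of what such a swap does. Within the data shown here, the only guide is the spread of the three numbers, and with so little to go on, any forecast stays rough. As compound 3 at 76.7 nm/s marks the top of that spread, a modest rise that stays inside it seems the reasonable expectation. The estimated move is a 1.7-fold higher number from compound 1 to compound 4 (0.23 log units; within the scatter), upward but no larger than the scatter. For compound 4 the estimate is 45 nm/s, with an expected range from 18 nm/s to 110 nm/s.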

Compound 4, apparent permeability: 80.2 nm/s
Compound 4: middle estimate off by 1.8-fold (0.25 log units), on the low side; the measured number falls inside the stated range.
By their numbers in this assay, from the lowest: compounds 1, 2, 3 and 4 (each within the scatter of the next, the first and the last beyond it).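

The series now holds its first change made in one place, read in this assay: phenyl in place of methoxycarbonyl on an aromatic carbon, para to a large group, gives a 3.0-fold higher number from compound 1 to compound 4 (0.48 log units; beyond the scatter). This shows that the number responds to what sits at this position, a point that compounds 1, 2 and 3 could not settle, as each of them differs from the others in more than one place. The change swaps a group with no ring that carries hydrogen-bond acceptors for a six-membered aromatic ring of carbon only that carries none, but no measurement here explains why the number rises.

This single step cannot separate the effect of adding a ring from that of losing the oxygen atoms of the ester, and a carboxylic acid, an amine or a simple ethyl group at the same position would each help to tell these apart. It also leaves open whether phenyl in place of methoxycarbonyl would give a similar step on a different core, or at another position on the aromatic ring.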